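This account rests on a few compounds, and the source may have more. Where it says the series, first, only, none or still open, it means among the compounds named here.

In a functional assay on C8166 cells (Homo sapiens) for cytotoxicity, read by MTT assay (a lower number here means that less compound is tolerated, a higher number that more compound is tolerated), compound 1 (`Cc1cc(S(N)(=O)=O)ccc1NC(=O)COc1ccc(Cl)cc1NC(=O)c1ccccc1`) gives 207000 nM, compound 2 (`Cc1ccc(C(=O)Nc2cc(Cl)ccc2OCC(=O)Nc2ccc(S(N)(=O)=O)cc2C)cc1`) gives 54200 nM, and compound 3 (`Cc1cc(S(N)(=O)=O)ccc1NC(=O)COc1ccc(Cl)cc1NC(=O)c1cccc(C(F)(F)F)c1`) gives 124000 nM. Compound 3 therefore sits close to compound 1, with a 1.7-fold lower number from compound 1 to compound 3 (0.22 log units; within the scatter), but clearly apart from compound 2, with a 2.3-fold higher number from compound 2 to compound 3 (0.36 log units; beyond the scatter). Compound 4 (`Cc1cc(C)cc(C(=O)Nc2cc(Cl)ccc2OCC(=O)Nc2ccc(S(N)(=O)=O)cc2C)c1`) has not yet been measured. It differs from compound 3 in one place: 3,5-dimethylphenyl in place of 3-(trifluoromethyl)phenyl on a carbonyl carbon. In words, this is 3,5-dimethylphenyl in place of 3-(trifluoromethyl)phenyl on a carbonyl carbon.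

Among the compounds with values here, two measured steps bear most directly on this change. Adding one methyl in place of hydrogen on an aromatic carbon gave a 3.8-fold lower number from compound 1 to compound 2 (0.58 log units; beyond the scatter), a modest step. The closest match to the present swap is a 2.3-fold higher number from compound 2 to compound 3 (0.36 log units; beyond the scatter), which is also modest and, read in reverse, points towards a lower number when a methyl-bearing group replaces the trifluoromethyl-bearing one. However, no measured compound carries two methyl groups, and the single methyl of compound 2 belongs to a 4-methylphenyl group, so the comparison is only approximate. A small move towards a lower number therefore seems most likely, and it may not rise above the scatter. The expected size of the change is a 1.6-fold lower number from compound 3 to compound 4 (0.19 log units; within the scatter). For compound 4, the estimated value is 80000 nM, with an expected range of 35000 nM to 180000 nM.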

Compound 4, half-maximal cytotoxic concentration: 36500 nM
Beside the measured number, compound 4's estimate is 2.2-fold (0.34 log units) above it, within the range that was stated.
By their numbers in this assay, from the lowest: compounds 4 and 2 (each within the scatter of the next); then compounds 3 and 1 (each within the scatter of the next).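

In this assay, putting 3,5-dimethylphenyl in place of 3-(trifluoromethyl)phenyl on the carbonyl carbon produces a clear step (a 3.4-fold lower number from compound 3 to compound 4 (0.53 log units; beyond the scatter)), and the new group also stands apart from plain phenyl (a 5.7-fold lower number from compound 1 to compound 4 (0.75 log units; beyond the scatter)). Yet compound 4 cannot be told apart from compound 2, which carries 4-methylphenyl (a 1.5-fold lower number from compound 2 to compound 4 (0.17 log units; within the scatter)), so across these compounds the two methyl-bearing groups sit together at the lower end of the numbers, while compound 3 stays within the scatter of compound 1, and a second methyl group, placed differently on the ring, brings no change beyond the scatter. The data shown offer no explanation for this grouping.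

Within the data shown here, with only two methyl-bearing groups in hand, the number of methyl groups and their places on the ring cannot be separated. The compounds shown also leave open where a phenyl group carrying an amine, a carboxylic acid or a longer chain such as ethyl would fall in this cell assay, and so how far the grouping extends beyond methyl.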